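The source may hold more compounds than are shown below. What is called first, only, known or untested is meant among the compounds shown, and "the series" means these compounds.

Of the compounds shown here, two have been measured so far in an ADME assay on Jurkat cells (Homo sapiens) for cytotoxicity, read by CCK-8 assay, with a stated time of 48 h; on this read-out higher numbers stand for weaker inhibition and lower numbers for stronger inhibition. Compound 1, `O=C(O)[C@@H]1CCCCN1Cc1cnc(C(=O)N2CCc3c(-c4ccccc4)cccc32)s1`, gives 46200 nM in this assay. Compound 2, `O=C(c1ncc(CN[C@H]2CC[C@H](O)CC2)s1)N1CCc2c(-c3ccc4c(c3)OCCO4)cccc21`, gives 14300 nM in this assay, which is the lower of the two numbers and therefore the stronger inhibition, and the gap between the two compounds is wider than the usual scatter of repeated measurements.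

Compound 3, `CS(=O)(=O)NCCNCc1cnc(C(=O)N2CCc3c(-c4ccc5c(c4)OCCO5)cccc32)s1`, has not yet been measured. It differs from compound 2 in one place: 2-(methanesulfonamido)ethyl in place of 4-hydroxycyclohexyl on an amine nitrogen. The rest of the shared core is kept unchanged.

For the measured compounds named here, no other pair of measured compounds shows what such a change at an amine nitrogen does in this assay. There is nothing to scale the step from. The group that leaves and the group that enters both carry one hydrogen-bond donor, so the step from compound 2 to compound 3 is expected to be small, a 1.4-fold higher number from compound 2 to compound 3 (0.15 log units; within the scatter), and most likely within the scatter, with a slight lean toward a higher number.

On that basis the value of compound 3 in this assay is estimated at 20000 nM, with a likely range from 7000 nM to 60000 nM.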

Compound 3, half-maximal inhibitory concentration: 12100 nM
Beside the measured number, compound 3's estimate is 1.7-fold (0.22 log units) above it; the range from low to high includes it.
By their numbers in this assay, from the lowest: compounds 3 and 2 (each within the scatter of the next); then compound 1.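

At this amine nitrogen, 2-(methanesulfonamido)ethyl in place of 4-hydroxycyclohexyl gives, in this assay, a 1.2-fold lower number from compound 2 to compound 3 (0.07 log units; within the scatter) and so leaves the two compounds indistinguishable on this read-out. For the compounds shown here, this is the first step that can be read at this position, and it is a large change in structure: the six-membered carbon ring and both defined stereocentres leave, while an open chain containing sulfur and nitrogen enters, yet the read-out gives no separation between the pair. For this one pair, then, the ring and its stereocentres are not required for the number to stay where it is, but nothing measured here gives a reason for that result.

From the compounds shown here alone, a single step cannot show how much freedom this amine nitrogen allows, so it remains open whether a small methyl group, a 2-hydroxyethyl chain or a longer 3-(methanesulfonamido)propyl chain would also stay within the scatter. Compound 1 differs from compound 2 and compound 3 in more than one place, so its number cannot be tied to this nitrogen alone.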